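Acid dissociation across four related secondary amines

A few compounds are considered here, and "the series" means these few. Any claim that something is new, unique, unknown or untested is made for them only; others in the source may bear on it.

Compound 2 `COc1cccc(Oc2ccc3c(NCCCNCc4ccco4)ccnc3c2)c1` and compound 1 `COc1cccc(Oc2ccc3c(NCCCNCc4cc(F)ccc4OC)ccnc3c2)c1` share one core. In a physicochemical assay for acid dissociation, compound 2 gives 9.28, and compound 1 gives 9.28. The change between them is 5-fluoro-2-methoxyphenyl in place of furan-2-yl on a saturated chain carbon bound to an amine nitrogen; the step it made is no change at the digits printed from compound 2 to compound 1 (within the scatter). Compound 3 `COc1ccc(-c2ccc3c(NCCCNCc4ccco4)ccnc3c2)cc1` carries a different core; how it differs from compound 2 is 4-methoxyphenyl in place of 3-methoxyphenoxy on an aromatic carbon, and the step is a number 0.19 log units higher from compound 2 to compound 3 (within the scatter). In this assay compound 3 gives 9.47. Compound 4 `COc1ccc(-c2ccc3c(NCCCNCc4cc(F)ccc4OC)ccnc3c2)cc1` is not yet measured; it differs from compound 3 by 5-fluoro-2-methoxyphenyl in place of furan-2-yl on a saturated chain carbon bound to an amine nitrogen, the same change as that from compound 2 to compound 1, at the same place. Because no change at the digits printed from compound 2 to compound 1 (within the scatter), the step from compound 3 to compound 4 in this assay is expected to be no change at the digits printed from compound 3 to compound 4 (within the scatter). Compound 4 is estimated at 9.47, expected between 9.2 and 9.75.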

Compound 4, acid dissociation constant: 9.47
Compound 4: the middle estimate sits on the measured number at the digits printed, and the stated range covers the measured number.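

In this assay, 5-fluoro-2-methoxyphenyl in place of furan-2-yl on a saturated chain carbon bound to an amine nitrogen reads the same on both cores (no change at the digits printed from compound 2 to compound 1 (within the scatter); no change at the digits printed from compound 3 to compound 4 (within the scatter)). The core change also reads the same with either group in place (a number 0.19 log units higher from compound 2 to compound 3 (within the scatter); a number 0.19 log units higher from compound 1 to compound 4 (within the scatter)). This shows that the change carries across these two cores with all steps within the scatter, but not that it would carry to any other core, and nothing measured here speaks to the reason.

Still open, as far as these compounds go, is whether the step would hold with a carboxylic acid or a second amine in place of furan-2-yl, or with a longer chain carrying the amine nitrogen.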